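Varying the aryl group on the carbonyl: compound 3 to compound 4

The source may hold more compounds than are shown below. What is called first, only, known or untested is meant among the compounds shown, and "the series" means these compounds.

Three measured compounds share one core and differ only in the aryl group attached to a carbonyl carbon. Compound 1 `CN(C(=O)NC(=O)c1ccccc1F)c1nc(C(F)(F)F)c(C(=O)N/N=C/c2ccccc2C(F)(F)F)s1` carries a 2-fluorophenyl there, and in a functional assay on A549 cells (Homo sapiens) for inhibition, read by MTT assay, with a stated time of 72 h (on this read-out lower numbers stand for stronger inhibition and higher numbers for weaker inhibition), compound 1 gives 6.32 ug/mL. Compound 2 `CN(C(=O)NC(=O)c1cccc([N+](=O)[O-])c1)c1nc(C(F)(F)F)c(C(=O)N/N=C/c2ccccc2C(F)(F)F)s1` carries a 3-nitrophenyl, and in this assay compound 2 gives 5.45 ug/mL. Compound 3 `CN(C(=O)NC(=O)c1ccc(C(F)(F)F)cc1)c1nc(C(F)(F)F)c(C(=O)N/N=C/c2ccccc2C(F)(F)F)s1` carries a 4-(trifluoromethyl)phenyl, and in this assay compound 3 gives 6.68 ug/mL. The steps between them are all small: a 1.2-fold lower number from compound 1 to compound 2 (0.06 log units; within the scatter), a 1.1-fold higher number from compound 1 to compound 3 (0.02 log units; within the scatter) and a 1.2-fold higher number from compound 2 to compound 3 (0.09 log units; within the scatter). Compound 3 thus has the highest of the three numbers, but its gaps to compound 1 and to compound 2 lie within the scatter, so no order can be read among the three.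

Compound 4 `CN(C(=O)NC(=O)c1ccc(Cl)cc1Cl)c1nc(C(F)(F)F)c(C(=O)N/N=C/c2ccccc2C(F)(F)F)s1` is not yet measured. Relative to compound 3 the change is 2,4-dichlorophenyl in place of 4-(trifluoromethyl)phenyl on a carbonyl carbon. Every measured step bears on this change, since each of them also exchanges the aryl group on the same carbonyl carbon, and none moved the read-out beyond the scatter. The expected step in this assay is therefore a 1.1-fold lower number from compound 3 to compound 4 (0.03 log units; within the scatter), nothing beyond the scatter. In this assay compound 4 is estimated at 6.2 ug/mL, with a range from 3.5 ug/mL to 11 ug/mL.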

Compound 4, half-maximal inhibitory concentration: 15.3 ug/mL
Estimate against measurement, compound 4: 2.5-fold (0.39 log units) below; measured number above the stated range.
By their numbers in this assay, from the lowest: compounds 2, 1 and 3 (each within the scatter of the next); then compound 4.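

In this assay, the aryl group on this carbonyl carbon, whose other neighbour is an amide-type nitrogen, no longer looks interchangeable: the 2,4-dichlorophenyl group gives a 2.3-fold higher number from compound 3 to compound 4 (0.36 log units; beyond the scatter), and against the other two earlier groups it gives a 2.8-fold higher number from compound 2 to compound 4 (0.45 log units; beyond the scatter) and a 2.4-fold higher number from compound 1 to compound 4 (0.38 log units; beyond the scatter). Each of these steps is modest, but all three lie beyond the scatter, so compound 4 stands apart from compounds 1, 2 and 3, which remain within the scatter of each other, and the change points towards weaker inhibition. Nothing in the data shown explains this shift.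

Whether the higher number goes with chlorine itself or with the particular 2,4-pattern stays open, as neither a 4-chlorophenyl nor a 2-chlorophenyl group stands among the compounds shown. Also open, on these data alone, is how an unsubstituted phenyl, a 4-methoxyphenyl or a cyclohexyl group on the same carbonyl carbon would read, and so whether compound 4 marks an isolated case or the edge of a wider trend.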